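Extending the carbamate ester from methyl to methoxyethyl

A few compounds are considered here, and "the series" means these few. Any claim that something is new, unique, unknown or untested is made for them only; others in the source may bear on it.

Of the compounds shown here, two from this series have been measured in a functional assay on CHO-K1 cells with Glucose-dependent insulinotropic receptor (Homo sapiens) as the target, read by a luciferase reporter, with a stated time of 5 h; a higher number here means a larger maximal response, a lower number a smaller maximal response. Compound 1 `CC(C)OC(=O)N1CCC(Oc2ncnc3c2CCN3c2ccc(-c3nccs3)cc2F)CC1` carries a propan-2-yl carbamate and a thiazolyl group on the fluorophenyl ring; in this assay compound 1 reaches 74%. Compound 2 `COC(=O)N1CCC(Oc2ncnc3c2CCN3c2ccc(S(C)(=O)=O)cc2F)CC1` instead carries a methyl carbamate and a methylsulfonyl group on the fluorophenyl ring; in this assay compound 2 reaches 119%, the higher of the two numbers, and the gap between them lies beyond the usual scatter. Going by the values given here, as the two compounds differ in two places at once, no single structural step between them is recorded.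

Compound 3 `COCCOC(=O)N1CCC(Oc2ncnc3c2CCN3c2ccc(S(C)(=O)=O)cc2F)CC1` keeps the methylsulfonyl-bearing core of compound 2 and differs only in the carbamate ester: methoxymethyl in place of hydrogen on a saturated chain carbon bound to an oxygen next to a carbonyl group. Among the compounds with values here, no measured pair in this set isolates such a change, so the expectation rests on compound 2 alone. The step is expected to be small, a number 9 percentage points lower from compound 2 to compound 3 (within the scatter), not beyond the scatter in either direction. Compound 3 is therefore estimated to reach 110% in this assay, with a plausible range from 85% to 135%.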

Compound 3, largest response reached (reported as percent of maximum), in percent of the reference or control that the assay uses: 86%
The estimate for compound 3 lay 24 percentage points above the measured number; measured number inside the range.
By their numbers in this assay, from the lowest: compound 1; then compound 3; then compound 2.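

The carbamate ester proves to be a position where the maximal response shifts: in this assay, extending methyl to 2-methoxyethyl gives a number 33 percentage points lower from compound 2 to compound 3 (beyond the scatter) while the methylsulfonyl-bearing core stays unchanged. Going by these compounds alone, this is the first reading of this position on its own, since compound 1 differs from compound 2 in two places and could not separate the carbamate ester from the group on the fluorophenyl ring. Nothing shown here explains the lower response that comes with the added methoxymethyl.

As far as these compounds go, what remains open is whether the step follows the added length of the chain or the presence of its ether oxygen, a question that a plain ethyl or propyl ester, with no such oxygen, or a 2-hydroxyethyl ester would begin to settle. From the compounds shown here alone, it also remains open whether the same extension would lower the response to a similar extent on the core of compound 1, which carries the thiazolyl group in place of methylsulfonyl.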